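The compounds below may be only part of what the source reports. "The series", "measured", "known", "first", "only" and "open" are said of these compounds alone.

In an ADME assay on HeLa cells (Homo sapiens) for cytotoxicity, read by MTT assay (a lower number here means a stronger inhibitor, a higher number a weaker inhibitor), compound 1 `COc1ccc(C[C@H]2COC(=O)[C@@H]2Cc2ccc(OCc3cn(-c4ccc(F)cc4)nn3)c(OC)c2)cc1OC` stands at >= 600000 nM, which is a limit of the assay and not a number. Among the measured compounds shown here, compound 2 `COc1ccc(C[C@H]2COC(=O)[C@@H]2Cc2ccc(OCC(=O)N3CCCCC3)c(OC)c2)cc1OC` gives 293000 nM, the only actual number so far. Compound 3 `COc1ccc(C[C@H]2COC(=O)[C@@H]2Cc2ccc(OCC(=O)N3CCCC3)c(OC)c2)cc1OC` differs from compound 2 in one place, on a carbonyl carbon: pyrrolidin-1-yl in place of piperidin-1-yl on a carbonyl carbon. For the measured compounds named here, the only measured step, an at least 2.0-fold lower number from compound 1 to compound 2 (0.31 log units; beyond the scatter), replaces a whole 1-(4-fluorophenyl)-1H-1,2,3-triazol-4-yl group, so it bears only loosely on this smaller ring change. No step beyond the scatter is therefore expected in this assay, and the estimated step is a 1.1-fold higher number from compound 2 to compound 3 (0.04 log units; within the scatter). Compound 3 is expected at 320000 nM, with an estimated range of 160000 nM to 600000 nM.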

Compound 3, half-maximal inhibitory concentration: >= 600000 nM
Compound 3 ended at the assay's limit (the forecaster's own chance of this, stated with the estimate: 20%); at least 1.8-fold (0.27 log units) between middle value and limit.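

In this assay, pyrrolidin-1-yl in place of piperidin-1-yl on a carbonyl carbon gives an at least 2.0-fold higher number from compound 2 to compound 3 (0.31 log units; beyond the scatter). This position therefore responds to a change from a six-membered to a five-membered non-aromatic ring, not only to the replacement of a whole 1-(4-fluorophenyl)-1H-1,2,3-triazol-4-yl group. The full size of this step is unknown, and the step between compound 1 and compound 3 cannot be read: the limit of >= 600000 nM in this assay, at which 2 of the 3 values shown sit.

Among the compounds shown here, compound 2 remains the only compound with an actual number. Open, from the compounds shown here alone, is what morpholin-4-yl, azepan-1-yl or an open-chain diethylamino group would give on the same carbonyl carbon.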